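A few compounds are considered here, and "the series" means these few. Any claim that something is new, unique, unknown or untested is made for them only; others in the source may bear on it.

Compound 1 `CCc1nc2c(-c3ccc(Cl)cc3Cl)ccnc2n1[C@@H](CC)C1CC1` gives 0.4 nM in an assay for binding affinity to Corticotropin releasing factor receptor (Rattus norvegicus); on this read-out lower numbers stand for stronger inhibition and higher numbers for weaker inhibition. Compound 2 `CCc1nc2c(-c3ccc(Cl)cc3Cl)ccnc2n1C(C)C1CCC1` gives 1 nM in this assay, and compound 3 `CCCC(C)n1c(CC)nc2c(-c3ccc(Cl)cc3Cl)ccnc21` gives 0.5 nM in this assay. Compound 3 thus holds the second highest number of the three, but both of its neighbours lie within the scatter, as a 1.3-fold higher number from compound 1 to compound 3 (0.10 log units; within the scatter) and a 2.0-fold lower number from compound 2 to compound 3 (0.30 log units; within the scatter) show; only a 2.5-fold higher number from compound 1 to compound 2 (0.40 log units; beyond the scatter) stands out as modest. Compound 4 `CCc1nc2c(-c3ccc(Cl)cc3Cl)ccnc2n1C(C)CC` differs from compound 3 by hydrogen in place of methyl on a saturated chain carbon, three bonds along the chain from an aromatic nitrogen. For the measured compounds named here, no measured step shortens this chain; the nearest comparison, a 2.0-fold lower number from compound 2 to compound 3 (0.30 log units; within the scatter), exchanges a ring for a chain on the same carbon and stays within the scatter. Only a small step is therefore expected, a 2.0-fold higher number from compound 3 to compound 4 (0.30 log units; within the scatter), if anything a slightly higher number. Compound 4 is estimated at 1 nM, within a range from 0.4 nM to 3 nM.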

Compound 4, inhibition constant: 1.3 nM
Compound 4: middle estimate off by 1.3-fold (0.11 log units), on the low side, within the range that was stated.
By their numbers in this assay, from the lowest: compounds 1, 3, 2 and 4 (each within the scatter of the next, the first and the last beyond it).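

Shortening 1-methylbutyl to sec-butyl is the first step here that changes only chain length and goes beyond the scatter, with a 2.6-fold higher number from compound 3 to compound 4 (0.41 log units; beyond the scatter) in this assay. The same sec-butyl group stays within the scatter of the cyclobutyl-bearing group, with a 1.3-fold higher number from compound 2 to compound 4 (0.11 log units; within the scatter), whereas a 3.3-fold higher number from compound 1 to compound 4 (0.51 log units; beyond the scatter) also lies beyond it. Nothing available accounts for these steps. The compounds shown leave open whether a chain longer than 1-methylbutyl would hold the number at this place. They also leave open what an amine or a hydroxyl on that chain would do.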